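The source may report more compounds than this note shows. Statements on the series, on what has been measured and on what is new or still open speak of the compounds shown alone.

Working notes on the series. Within the data shown here, in an assay on CHO cells for displacement of a labelled ligand from histamine receptor H3 (Macaca mulatta) (on this read-out lower numbers stand for stronger inhibition and higher numbers for weaker inhibition), compound 1, `CC1CCCN1C1CCN(c2ccc(NC(=O)CC3CCCC3)cc2)C1`, gives 3.1 nM, the lowest of the three numbers measured so far. Compound 2, `Cc1cc(N2CCC(N3CCCC3C)C2)ccc1NC(=O)C1CCOCC1`, gives 6.8 nM in this assay, a gap to compound 1 that lies beyond the usual scatter. Compound 3, `Cc1cc(NC(=O)C2CC3CCC2C3)ccc1N1CCC(N2CCCC2C)C1`, gives 130 nM in this assay, the weakest of the three by a margin well beyond the scatter. Compound 3 differs from compound 1 in more than one place, so its number says nothing on its own about any single change; only the two values stand side by side.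

The next compound, compound 4, `CC1CCCN1C1CCN(c2ccc(NC(=O)C3CC3)cc2)C1`, keeps the core of compound 1 and changes only the acyl group: cyclopropyl in place of cyclopentylmethyl on a carbonyl carbon. Among the measured compounds shown here, no measured pair isolates this change. The two measured amides with smaller or ring-containing acyl groups, compound 1 and compound 2, both sit in the low range, while the largest acyl group, in compound 3, sits far higher; a three-membered ring is the smallest group in the set. The step from compound 1 to compound 4 is expected to be small, a 1.9-fold higher number from compound 1 to compound 4 (0.29 log units; within the scatter), a modest move toward weaker inhibition at most, close to the scatter. Compound 4 is therefore expected to give about 6 nM in this assay, with a range from 2 nM to 20 nM.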

Compound 4, inhibition constant: 9.7 nM
Beside the measured number, compound 4's estimate is 1.6-fold (0.21 log units) below it; the measured number falls inside the stated range.
By their numbers in this assay, from the lowest: compound 1; then compounds 2 and 4 (each within the scatter of the next); then compound 3.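

In this assay, the acyl group on the core of compound 1 now has its first isolated step, a 3.1-fold higher number from compound 1 to compound 4 (0.50 log units; beyond the scatter), with cyclopropyl in place of cyclopentylmethyl on a carbonyl carbon. The number at this position therefore responds to the acyl group even when both groups are all-carbon rings with 0 hydrogen-bond donors and 0 hydrogen-bond acceptors, although the step is only modest as the heavy-atom count falls from 6 to 3. No measurement shown accounts for this step, so its cause remains unassigned.

The compounds shown leave open how a straight butyl chain or a cyclopentyl group attached directly to the carbonyl carbon would read on the core of compound 1, and so whether the step follows the ring size, the carbon count or the presence of the chain carbon in cyclopentylmethyl. Also open, going by these compounds, is how an amine or a hydroxyl group on the acyl group would read at this position.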